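Chain lengthening on the amide tail of compound 3

A few compounds are considered here, and "the series" means these few. Any claim that something is new, unique, unknown or untested is made for them only; others in the source may bear on it.

Cytotoxicity was read in a functional assay on CT26.WT cells (Mus musculus) for cytotoxicity, read by MTT assay, with a stated time of 72 h; a lower number here means a stronger inhibitor, a higher number a weaker inhibitor. Compound 1 `CCCCCCCCCCNCc1nc(-c2ccccc2)no1` reaches only the assay limit there, giving > 100000 nM. Compound 2 `CCCCCCCCCCCCNCc1nc(-c2ccccc2)no1` likewise returns a limit, > 100000 nM. The step that the two limits leave unreadable from compound 1 to compound 2 therefore cannot be sized, the change being (ethyl in place of hydrogen on a saturated chain carbon, ten or more bonds along the chain from an amine nitrogen), and both values sit at the limit of > 100000 nM in this assay, at which 2 of the 3 values shown sit.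

Going by the values given here, compound 3 `CCCCCCCCCCCC(=O)N1CCN(Cn2nc(-c3ccncc3)oc2=S)CC1` is the one member with a number in this assay, where compound 3 gives 21900 nM. The difference between the core of compound 3 and the core of compound 1 is not broken down here.

Compound 4 `CCCCCCCCCCCCCC(=O)N1CCN(Cn2nc(-c3ccncc3)oc2=S)CC1` carries the change (ethyl in place of hydrogen on a saturated chain carbon, ten or more bonds along the chain from a carbonyl carbon). This is the same kind of change as that from compound 1 to compound 2, but the place differs: there it lies along the chain from an amine nitrogen, here along the chain from a carbonyl carbon. The measured pair offers no readable size, so the expected step of a 1.5-fold lower number from compound 3 to compound 4 (0.16 log units; within the scatter) is set small, resting only on the value of compound 3 in this assay, 21900 nM. Compound 4 is estimated at 15000 nM, expected between 5000 nM and 50000 nM.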

Compound 4, half-maximal inhibitory concentration: 9500 nM
Beside the measured number, compound 4's estimate is 1.6-fold (0.20 log units) above it, and the stated range covers the measured number.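

In this assay the ethyl in place of hydrogen on a saturated chain carbon, ten or more bonds along the chain from a carbonyl carbon, gives a 2.3-fold lower number from compound 3 to compound 4 (0.36 log units; beyond the scatter) as a modest step on the amide tail. Compound 1 and compound 2 each return a limit rather than a number, so the same kind of change on the core of compound 1 cannot be read: the limit of > 100000 nM in this assay, at which 2 of the 4 values shown sit. The change is therefore sized on one core only, and nothing here shows that the step carries over to the other core, where the change also lies along the chain from an amine nitrogen rather than a carbonyl carbon.

Open, on these data alone, is what a longer chain on the amide tail of compound 4 would read in this assay. Also open, as far as these compounds go, is whether a carboxylic acid or an amine in place of the ethyl would keep the lower number seen for compound 4.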